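This account rests on a few compounds, and the source may have more. Where it says the series, first, only, none or still open, it means among the compounds named here.

Series notes, shared core with a propyl chain on the ring carbon in compound 1 `CCCc1cn(CC=C(C)C)nn1` and compound 2 `CCCc1cn(C/C=C(\C)CCC=C(C)C)nn1`. In a physicochemical assay for lipophilicity, measured as octanol-water partition (a lower number here means a more polar compound, a higher number a more lipophilic compound), compound 1 gives 2.47, the lower of the two numbers in hand; compound 2 gives 4.5. Within the data shown here, the one measured step, a number 2.03 log units higher from compound 1 to compound 2 (beyond the scatter), is the only calibration available and lies well beyond the scatter.

Compound 3 `CCCCCc1cn(CC=C(C)C)nn1` is not yet measured in this assay. It differs from compound 1 by ethyl in place of hydrogen on a saturated chain carbon, three bonds along the chain from an aromatic carbon, which read one bond further out is propyl to pentyl. The step from compound 1 to compound 2 bears on it only loosely: that step added a larger unsaturated chain at a different place, whereas the change to compound 3 adds ethyl on the saturated chain. A move upward in this assay is therefore expected, smaller than the measured step and beyond the scatter, estimated as a number 0.93 log units higher from compound 1 to compound 3 (beyond the scatter).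

Compound 3 is estimated at 3.4, with the range 3 to 3.8 in this assay.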

Compound 3, partition coefficient: 3.46
For compound 3 the middle estimate is 0.06 log units below the measured one; low and high end bracket the measured number.
By their numbers in this assay, from the lowest: compound 1; then compound 3; then compound 2.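

The propyl to pentyl change shows that the saturated chain on the shared core is a place where this assay responds: ethyl in place of hydrogen on a saturated chain carbon, three bonds along the chain from an aromatic carbon, gives a number 0.99 log units higher from compound 1 to compound 3 (beyond the scatter) in this series. The only earlier calibration, a number 2.03 log units higher from compound 1 to compound 2 (beyond the scatter), came from a change at a different place, so the number is now seen to move beyond the scatter from two separate places on compound 1, with ethyl giving the smaller of the two steps and 3-methylbut-2-en-1-yl the larger. No measurement in hand accounts for the size of either step.

On these data alone, whether the rise carries on with a longer chain such as heptyl, or how an amine or a carboxylic acid in place of the pentyl chain would read, stays open. Also open, as far as these compounds go, is whether the pentyl chain and the larger unsaturated chain of compound 2 would add up when carried together on the shared core.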